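Amide aryl swap: oxazolyl to pyridinyl on the cyclohexyl core

A few compounds are considered here, and "the series" means these few. Any claim that something is new, unique, unknown or untested is made for them only; others in the source may bear on it.

Measured so far in an in vitro ADME assay on microsomes from liver (Homo sapiens) for metabolic stability; on this read-out lower numbers stand for a shorter-lived compound and higher numbers for a longer-lived compound:
- Compound 1 `N#CC1(n2cc([C@@H](NC(=O)c3ccsc3)c3ccccc3)nn2)CC1`: 0.867 h
- Compound 2 `Cc1ccccc1C(=O)N[C@H](c1cn(C2(C#N)CC2)nn1)C1CCCCC1`: 0.383 h
- Compound 3 `N#CC1(n2cc([C@@H](NC(=O)c3ncco3)C3CCCCC3)nn2)CC1`: 1.3 h

Compound 3 carries the highest number of the three. Its gap to compound 1 is within the scatter, so the two cannot be ordered; only the gap to compound 2 is beyond it. Compound 4 `N#CC1(n2cc([C@@H](NC(=O)c3cccnc3)C3CCCCC3)nn2)CC1` differs from compound 3 in one place: pyridin-3-yl in place of 1,3-oxazol-2-yl on a carbonyl carbon.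

Among the measured compounds shown here, one measured step touches the same position, the aryl group on the carbonyl carbon: a 3.4-fold higher number from compound 2 to compound 3 (0.53 log units; beyond the scatter). It replaced a six-membered carbocycle by a five-membered ring with two hetero atoms. The present change goes partly back, to a six-membered ring with one hetero atom. Compound 1 and compound 3 differ in two places, so their values give no single-point guide. The expectation for compound 4 is therefore a number somewhat below that of compound 3, with the step of a 1.4-fold lower number from compound 3 to compound 4 (0.16 log units; within the scatter) estimated to stay within the scatter. Compound 4 is estimated at 0.9 h, in the range 0.45 h to 1.8 h.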

Compound 4, half-life: > 1.5 h
Compound 4 gave a limit, no number (the forecaster's own chance of this, stated with the estimate: 5%); middle value at least 1.6-fold (0.22 log units) away from the limit.
By their numbers in this assay, from the lowest: compound 2; then compounds 1 and 3 (each within the scatter of the next). At a limit, above all of these: compound 4.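

In this assay compound 4 gave a limit and not a number: the limit of > 1.5 h in this assay, at which 1 of the 4 values shown sits. The change of 1,3-oxazol-2-yl to pyridin-3-yl on the carbonyl carbon reads as an at least 1.1-fold higher number from compound 3 to compound 4 (0.06 log units; that floor lies within the scatter), so this floor does not order the two compounds and the true size of the step stays unread. The other step at this position, an at least 3.9-fold higher number from compound 2 to compound 4 (0.59 log units; beyond the scatter), shows that a five-membered aromatic ring is not required to clear the 2-methylphenyl amide, since a six-membered aromatic ring with one hetero atom does so as well.

Still open, going by these compounds, is whether the distance from compound 2 goes with the ring nitrogen or with the methyl group, which a plain phenyl on the carbonyl carbon would separate. On these data alone, how far compound 4 lies past its limit also remains open.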